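The compounds below may be only part of what the source reports. "The series", "measured", "known", "first", "only" and "open" are said of these compounds alone.

Measured so far:
compound 1 `CCCCCCCC/C=C\c1c(C)cc(C)nc1CCCOC` gives 31.7 uM
compound 2 `CCCCCCCCCCc1c(C)c(CCCCCCCCCC)c2[n+](c1C)CCC2` gives 1.9 uM
compound 3 `CCCCCCCC/C=C\c1c(C)c(/C=C\CCCCCCCC)c2[n+](c1C)CCC2` gives 3.3 uM

All three values come from a functional assay on M12 cells (Homo sapiens) for antiproliferative activity, read by WST assay, with a stated time of 72 h; a higher number here means that more compound is needed for the effect, a lower number that less compound is needed. Compound 2, at 1.9 uM, stands at the low end of the series together with compound 3, at 3.3 uM, and the two lie within the scatter of each other. Compound 1, at 31.7 uM, has a number well beyond the scatter from compound 2.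

The next compound is compound 4 `CCCCCCCCCCc1c(C)cc(C)[n+]2c1CCC2`, in which hydrogen replaces decyl on an aromatic carbon of compound 2: hydrogen in place of decyl on an aromatic carbon. Going by the values given here, no measured pair isolates this change, so any expectation in this assay is loose. Among the compounds with values here, the one guide is that compound 1, at 31.7 uM, shows that numbers in this small set can lie far higher than that of compound 2. A rise beyond the scatter is therefore expected, and the estimate is a 6.3-fold higher number from compound 2 to compound 4 (0.80 log units; beyond the scatter). For compound 4 the estimated value is 12 uM, with an expected range of 4 uM to 40 uM.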

Compound 4, concentration for half-maximal effect: 0.9 uM
The estimate for compound 4 lay 13-fold (1.12 log units) above the measured number; measured number below the stated range.
By their numbers in this assay, from the lowest: compound 4; then compounds 2 and 3 (each within the scatter of the next); then compound 1.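

In this assay, hydrogen in place of decyl on this aromatic carbon, two atoms from the ring nitrogen, gives a 2.1-fold lower number from compound 2 to compound 4 (0.32 log units; beyond the scatter). The step is modest but beyond the scatter, and it shows that a decyl group at this position is not needed for the antiproliferative effect, as compound 4 needs less compound without it. The data offer no measurement that accounts for this step.

From the compounds shown here alone, only decyl and hydrogen stand at this carbon, so it remains open how a butyl chain, a hydroxyl group or a carboxylic acid would compare there. Going by these compounds, it is also open whether replacing the remaining decyl group of compound 4 with hydrogen would move the number in the same direction.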